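This account rests on a few compounds, and the source may have more. Where it says the series, first, only, none or still open, it means among the compounds named here.

Compounds measured so far in a functional assay on MDA-MB-231 cells (Homo sapiens) for antiproliferative activity, read by MTT assay, with a stated time of 24 h; on this read-out higher numbers stand for weaker inhibition and lower numbers for stronger inhibition:
compound 1, `O=C(NNC(=O)c1cccc(Cl)c1)c1ccc(NS(=O)(=O)c2cnc(O)nc2O)cc1`, gives 4160 nM.
compound 2, `O=C(NNC(=O)c1ccccc1F)c1ccc(NS(=O)(=O)c2cnc(O)nc2O)cc1`, is reported only as a limit of the assay, > 20000 nM.
compound 3, `O=C(NNC(=O)c1cccc(NS(=O)(=O)c2cnc(O)nc2O)c1)c1cccc(Cl)c1`, gives 3180 nM.

Compound 1 and compound 3 are built from the same atoms joined differently; the difference between their two cores is not broken down here. Their values in this assay lie within the usual scatter of each other, so nothing separates them.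

One change has already been tested once: 2-fluorophenyl in place of 3-chlorophenyl on a carbonyl carbon. That step, an at least 4.8-fold higher number from compound 1 to compound 2 (0.68 log units; beyond the scatter), is known only as a lower bound because the limit of > 20000 nM in this assay, at which 1 of the 3 values shown sits, caps what the assay reports.

Compound 4, `O=C(NNC(=O)c1ccccc1F)c1cccc(NS(=O)(=O)c2cnc(O)nc2O)c1`, carries the same change on the core of compound 3: 2-fluorophenyl in place of 3-chlorophenyl on a carbonyl carbon. The place is described in the same words both times, so this is the same change. Starting from compound 3 and applying a step like the one from compound 1 to compound 2, compound 4 is expected to weaken by about a 5.7-fold higher number from compound 3 to compound 4 (0.75 log units; beyond the scatter). The estimate for compound 4 is therefore 18000 nM, likely between 8000 nM and 45000 nM, and it may well come back only as a limit.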

Compound 4, half-maximal inhibitory concentration: > 20000 nM
Compound 4 gave a limit, no number (the forecaster's own chance of this, stated with the estimate: 55%); middle value at least 1.1-fold (0.04 log units) away from the limit.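

In this assay compound 4 gives > 20000 nM which is a limit of the assay and not a number. Putting 2-fluorophenyl in place of 3-chlorophenyl on a carbonyl carbon gives an at least 6.2-fold higher number from compound 3 to compound 4 (0.79 log units; beyond the scatter) and so points the same way as the earlier step on the other core. The change therefore carries over from one core to the other in direction, with inhibition weaker on both, but how large it really is on each core, and whether those sizes match, stays unknown: the same change on two cores in this assay, an at least 4.8-fold higher number (0.68 log units; beyond the scatter) from compound 1 to compound 2 and an at least 6.2-fold higher number (0.79 log units; beyond the scatter) from compound 3 to compound 4; the limit leaves it open whether they differ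

The two groups differ both in the halogen and in where it sits, so the compounds shown cannot tell which of these two differences goes with the weaker inhibition. Still open, on these data alone, is how 2-chlorophenyl or 3-fluorophenyl, which would pull these two differences apart, would behave on either core.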